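This account rests on a few compounds, and the source may have more. Where it says the series, first, only, none or still open, it means among the compounds named here.

In an ADME assay on the whole organism (strain Sprague-Dawley) for pharmacokinetics, with Rattus norvegicus as the target, read by LC-MS, at a dose of 10 mg/kg by the oral route (on this read-out lower numbers stand for lower exposure and higher numbers for higher exposure at the dose given), compound 1 (`CC#C[C@@H](CC(=O)O)c1ccc(OC[C@H]2COc3ccc(Cl)cc3O2)cc1`) gives 124000 nM and compound 2 (`CC#C[C@@H](CC(=O)O)c1ccc(OC[C@H]2COc3ccccc3O2)cc1`) gives 104000 nM. With only these two numbers in the series, compound 2 stands within the scatter of compound 1, and no order can be read between them. The next structure is compound 3 (`CC#C[C@@H](CC(=O)O)c1ccc(OC[C@H]2COc3ccc(C)cc3O2)cc1`), reached from compound 2 by one change: methyl in place of hydrogen on an aromatic carbon. In words, this is methyl in place of hydrogen on an aromatic carbon, on a six-membered aromatic ring of carbon only that is part of a fused system of two rings. No measured compound in the series carries this methyl, so its effect on the read-out is not shown directly. Within the data shown here, the one measured step that bears on it is also a change on an aromatic carbon, hydrogen in place of chloro (a 1.2-fold lower number from compound 1 to compound 2 (0.08 log units; within the scatter)), and that step stays within the scatter. On that single step, no change beyond the scatter is expected, and no direction can be assigned. The estimated step (a 1.1-fold higher number from compound 2 to compound 3 (0.02 log units; within the scatter)) is therefore small. In this assay compound 3 is estimated at 110000 nM with an expected range from 60000 nM to 200000 nM.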

Compound 3, maximal plasma concentration: 64600 nM
For compound 3 the middle estimate is 1.7-fold (0.23 log units) above the measured one; measured number inside the range.
By their numbers in this assay, from the lowest: compounds 3, 2 and 1 (each within the scatter of the next).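

In this assay, methyl on this aromatic carbon gives a 1.6-fold lower number from compound 2 to compound 3 (0.21 log units; within the scatter), and the comparison with chloro at the same place gives a 1.9-fold lower number from compound 1 to compound 3 (0.28 log units; within the scatter). Hydrogen, chloro and methyl have now all been read at this one place, on an aromatic carbon of the six-membered aromatic ring of carbon only, and none of the printed steps among compounds 1, 2 and 3 lies beyond the scatter. Among these compounds, on this read-out the three groups are therefore not separated, which extends the single chloro-to-hydrogen step to a second incoming group, and no evidence on hand bears on the reason for these numbers.

Still open, as far as these compounds go, is whether any group on this aromatic carbon, such as a methoxy, a trifluoromethyl or an amine, gives a step beyond the scatter in this assay. Also open is whether the same methyl on another aromatic carbon of the fused system would read the same way, since all three compounds shown differ at this single place.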